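Removing the Oxan-4-yl Group from a Chemokine Receptor Antagonist

The source may hold more compounds than are shown below. What is called first, only, known or untested is meant among the compounds shown, and "the series" means these compounds.

Of the compounds shown here, three sharing one core have been measured for their ability to block signalling at the receptor. Compound 1 `C[C@@H]1CN(c2sc(C(F)(F)F)nc2-c2nc3ccccc3[nH]2)CCN1C(=O)Cn1ccc(C(=O)O)n1` carries an acid-bearing head group, and in a functional assay on Venous blood for antagonist activity at C-X-C chemokine receptor type 3 (Homo sapiens), read by flow cytometry, with a stated time of 30 min, in the presence of a further agent that is not named here (a higher number here means a weaker inhibitor, a lower number a stronger inhibitor), compound 1 gives 5570 nM. Compound 2 `Cc1nc(C)n(CC(=O)N2CCN(c3sc(C(F)(F)F)nc3-c3nc4c(F)cccc4[nH]3)C[C@H]2C)n1` bears a fluorine on its fused ring system together with a dimethyltriazole head, and in this assay compound 2 gives 321 nM. Compound 3 `Cc1nc(C)n(CC(=O)N2CCN(c3sc(C(F)(F)F)nc3-c3nc4ccc(C5CCOCC5)cc4[nH]3)C[C@H]2C)n1` keeps the same head group but carries an oxan-4-yl group on the fused ring, and in this assay compound 3 gives 123 nM, the lowest of the three numbers, with compound 2 its nearest neighbour and compound 1 far away.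

Compound 4 `Cc1nc(C)n(CC(=O)N2CCN(c3sc(C(F)(F)F)nc3-c3nc4ccccc4[nH]3)C[C@H]2C)n1` is the next step. Relative to compound 3, it has hydrogen in place of oxan-4-yl on an aromatic carbon. Among the compounds with values here, no measured pair shows this particular change on its own, so its effect can only be guessed from how much the substituted compounds 2 and 3 outperform the unsubstituted compound 1, which also differs in its head group. It is estimated that stripping the ring back to hydrogen costs some potency, a moderate step upward in this assay from compound 3 to compound 4 of a 3.3-fold higher number from compound 3 to compound 4 (0.51 log units; beyond the scatter). Compound 4 is therefore expected to give about 400 nM, within a range of 150 nM to 1200 nM.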

Compound 4, half-maximal inhibitory concentration: 237 nM
The estimate for compound 4 lay 1.7-fold (0.23 log units) above the measured number, and the stated range covers the measured number.
By their numbers in this assay, from the lowest: compounds 3, 4 and 2 (each within the scatter of the next, the first and the last beyond it); then compound 1.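

Compound 4 supplies the first unsubstituted partner for the dimethyltriazole head. In this assay, hydrogen in place of oxan-4-yl gives a 1.9-fold higher number from compound 3 to compound 4 (0.28 log units; within the scatter), and hydrogen in place of fluoro gives a 1.4-fold lower number from compound 2 to compound 4 (0.13 log units; within the scatter); both steps lie within the scatter, so neither group, taken alone, is shown to change the read-out. Compound 4 also isolates the head group, where 3,5-dimethyl-1H-1,2,4-triazol-1-yl in place of 3-carboxy-1H-pyrazol-1-yl gives a 24-fold lower number from compound 1 to compound 4 (1.37 log units; beyond the scatter), a large step beyond the scatter and the only one of the three single changes that is. No measurement available here bears on what lies behind these steps.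

The compounds shown leave open whether an amine or a longer chain in place of the oxan-4-yl group, on the same aromatic carbon, would move the number beyond the scatter. They also leave open whether an ester or an amide in place of the carboxylic acid on the pyrazole head would stay close to compound 1 or come closer to compound 4.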